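A few compounds are considered here, and "the series" means these few. Any claim that something is new, unique, unknown or untested is made for them only; others in the source may bear on it.

Working notes on the series. Going by the values given here, in a functional assay on 786-0 cells (Homo sapiens) for inhibition, read by sulforhodamine B assay, with a stated time of 48 h (on this read-out higher numbers stand for lower toxicity in this test and lower numbers for higher toxicity in this test), compound 2 `COc1ccc(Sc2nc3cc(N)cc(N)c3nc2-c2ccccc2)cc1` gives 70800 nM, the only plain number this set holds so far. Compound 1 `COc1ccc(CNc2nc3cc(N)cc(N)c3nc2-c2ccccc2)cc1` stands only as a limit of the assay, < 100000 nM, which is what the limit of < 100000 nM in this assay, at which 1 of the 2 values shown sits, records. Among the compounds with values here, no step between two measured compounds can be drawn, since compound 1 carries no number and compound 2 is alone with its value. Compound 3 `Nc1cc(N)c2nc(-c3ccccc3)c(Oc3ccc(F)cc3)nc2c1` is still to be measured in this assay. It differs from compound 2 by 4-fluorophenoxy in place of (4-methoxyphenyl)sulfanyl on an aromatic carbon. With the rest of the structure kept, the change is expected to shift the read-out by little: the expected step is a 1.2-fold lower number from compound 2 to compound 3 (0.07 log units; within the scatter), not beyond the usual scatter. Compound 3 is accordingly estimated at 60000 nM in this assay, with a range from 25000 nM to 150000 nM.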

Compound 3, concentration lethal to 50% of the cells: 75900 nM
Compound 3: middle estimate off by 1.3-fold (0.10 log units), on the low side, within the range that was stated.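

In this assay, going by these compounds alone, the step at this aromatic carbon is a 1.1-fold higher number from compound 2 to compound 3 (0.03 log units; within the scatter), the first readable step, and it does not separate 4-fluorophenoxy from (4-methoxyphenyl)sulfanyl. Within the data shown here, both the atom linking the ring to the core and the substituent on that ring differ in this change, so the one step covers both differences and neither can be read alone. Compound 1 remains a limit of the assay, and steps to it cannot be read: the limit of < 100000 nM in this assay, at which 1 of the 3 values shown sits.

Still open, on these data alone, is whether any group on this carbon moves the number beyond the scatter, for instance a carboxylic acid, a primary amine or a longer alkyl chain. Also open, as far as these compounds go, is how phenoxy without the fluorine compares with 4-fluorophenoxy at this place.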